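The source may report more compounds than this note shows. Statements on the series, on what has been measured and on what is new or still open speak of the compounds shown alone.

Measured compounds:
compound 1, `Cc1cccc(NC(=O)[C@H]2CN(C)C[C@@H]2c2ccc(/C=C/C(=O)Nc3ccccc3N)cc2)c1`: 14 mL/min/kg
compound 2, `COc1cccc(NC(=O)[C@H]2CN(C)C[C@@H]2c2ccc(/C=C/C(=O)Nc3ccccc3N)cc2)c1`: 14 mL/min/kg

Both compounds were tested in an in vitro ADME assay on microsomes from liver (Homo sapiens) for pharmacokinetics, read by LC-MS, with a stated time of 10 min, tested at 1 uM; a higher number here means faster removal of the compound, a lower number slower removal. Among the measured compounds shown here, compound 2 stands level with compound 1 at the digits given, and it has no other measured neighbour; the single measured step, no change at the digits printed from compound 1 to compound 2 (within the scatter), is within the scatter. For the measured compounds named here, that step swaps a methoxy for a methyl on an aromatic carbon, so the only evidence in hand is that this exchange on the aryl group did not move the clearance.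

Compound 3, `Cc1cc(NC(=O)[C@H]2CN(C)C[C@@H]2c2ccc(/C=C/C(=O)Nc3ccccc3N)cc2)ccc1Cl`, is not yet measured. It differs from compound 2 by 4-chloro-3-methylphenyl in place of 3-methoxyphenyl on an amide-type nitrogen. Going by the values given here, the one measured step bears on this only in part: it covers the loss of the methoxy, and the return of a methyl, but it says nothing about the chlorine that enters with it. The data therefore give no ground for a step beyond the scatter in either direction, and the estimate stays close to the two measured values, with a range widened for the untested chlorine.

Compound 3 is expected to give 16 mL/min/kg in this assay, between 8 mL/min/kg and 32 mL/min/kg. The expected step of a 1.1-fold higher number from compound 2 to compound 3 (0.06 log units; within the scatter) is within the scatter.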

Compound 3, clearance: 15 mL/min/kg
For compound 3 the middle estimate is 1.1-fold (0.03 log units) above the measured one; the range from low to high includes it.
By their numbers in this assay, from the lowest: compounds 1, 2 and 3 (each within the scatter of the next).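

In this assay, among the compounds shown here, the step of a 1.1-fold higher number from compound 1 to compound 3 (0.03 log units; within the scatter) is the first measured one to bring a chlorine onto the aryl group, as chloro in place of hydrogen on an aromatic carbon. The wider exchange of 4-chloro-3-methylphenyl for 3-methoxyphenyl on an amide-type nitrogen gives a 1.1-fold higher number from compound 2 to compound 3 (0.03 log units; within the scatter) and so replaces the single hydrogen-bond acceptor of the leaving group with a group that has none, while the heavy-atom count stays the same; the earlier pair, with its methoxy for methyl exchange, did not cover either of these changes. Across compounds 1, 2 and 3, the clearance therefore stays level within the scatter for these three substituted phenyl groups, though no measurement offered here accounts for that result.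

The compounds shown all keep a substituted phenyl ring on the amide nitrogen and leave open how clearance would respond to a basic aliphatic amine or a carboxylic acid on that ring, or to a cyclohexyl group in its place. They also leave open what would follow from changing the shared core, such as replacing its N-methyl group with a longer alkyl chain.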